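The compounds below may be only part of what the source reports. "The series", "measured", "known", "first", "only" and "open" are said of these compounds alone.

Compound 1 `COc1cc(N(C)C)c(NC(=O)c2ccnc(Cl)c2)cc1Nc1nccc(-c2cn(C)c3ccccc23)n1`: 9200 nM
Compound 2 `COc1cc(N(C)C)c(NC(=O)c2ccncc2OC)cc1Nc1nccc(-c2cn(C)c3ccccc23)n1`: 12100 nM
Compound 3 `COc1cc(N(C)CCN(C)C)c(NC(=O)c2ccnc(Cl)c2)cc1Nc1nccc(-c2cn(CCCO)c3ccccc23)n1`: 1820 nM

These three compounds were tested in a functional assay on NCI-H1975 cells (Homo sapiens) for antiproliferative activity, read by MTT assay, with a stated time of 72 h; a lower number here means a stronger inhibitor, a higher number a weaker inhibitor. Compound 1 gives 9200 nM and compound 2 gives 12100 nM. The two differ at one point only, (3-methoxypyridin-4-yl in place of 2-chloropyridin-4-yl on a carbonyl carbon), and that change gives a 1.3-fold higher number from compound 1 to compound 2 (0.12 log units; within the scatter), so in this assay the pair looks alike. Compound 3 gives 1820 nM, the lowest of the three numbers, set apart from both of the others beyond the scatter. The difference between the core of compound 3 and the core of compound 1 is not broken down here.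

Compound 4 `COc1cc(N(C)CCN(C)C)c(NC(=O)c2ccncc2OC)cc1Nc1nccc(-c2cn(CCCO)c3ccccc23)n1` has not yet been measured. It stands to compound 3 exactly as compound 2 stands to compound 1: 3-methoxypyridin-4-yl in place of 2-chloropyridin-4-yl on a carbonyl carbon, the same change at the same place, occurring twice among these compounds. A step of similar size is expected here, a 1.3-fold higher number from compound 3 to compound 4 (0.12 log units; within the scatter), because the same change once gave a 1.3-fold higher number from compound 1 to compound 2 (0.12 log units; within the scatter). That rests on a single measured pair, so the range is kept wide. Compound 4 is estimated at 2400 nM, expected to fall between 1200 nM and 5000 nM.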

Compound 4, half-maximal inhibitory concentration: 1970 nM
Beside the measured number, compound 4's estimate is 1.2-fold (0.09 log units) above it, within the range that was stated.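

In this assay the same swap, 3-methoxypyridin-4-yl in place of 2-chloropyridin-4-yl on a carbonyl carbon, gives a 1.1-fold higher number from compound 3 to compound 4 (0.03 log units; within the scatter), so on this second core the two compounds again look alike. Set side by side, the two measured pairs agree: the same change on two cores in this assay, a 1.3-fold higher number (0.12 log units; within the scatter) from compound 1 to compound 2 and a 1.1-fold higher number (0.03 log units; within the scatter) from compound 3 to compound 4, 1.2-fold (0.08 log units) apart, within the scatter of two such steps. This shows that on these two cores the swap carries over without a change that can be told from the scatter, but two pairs from one cell assay say nothing about other cores or other assays, and they do not explain why the number stays put.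

As far as these compounds go, it remains open whether a different group on the carbonyl carbon, such as a plain phenyl ring or a pyridine carrying an amine, would shift the number. From the compounds shown here alone, it is also open which part of the difference between the core of compound 3 and the core of compound 1 goes with the lower number of compound 3, as those cores differ in more than one place.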